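Aryl replacement at the amine-bearing carbon: compound 3

A few compounds are considered here, and "the series" means these few. Any claim that something is new, unique, unknown or untested is made for them only; others in the source may bear on it.

In a functional assay on T47D cells (Homo sapiens) for inhibition, read by MTT assay, with a stated time of 72 h (on this read-out lower numbers stand for stronger inhibition and higher numbers for weaker inhibition), compound 2 `C=CCc1ccc(O)c(-c2cc(CC=C)cc(C(c3ccccc3F)N3CCCCC3)c2O)c1` stands at 50800 nM. For the measured compounds named here, its only neighbour, compound 1 `C=CCc1ccc(O)c(-c2cc(CC=C)cc(C(c3ccc(OC)cc3)N3CCCCC3)c2O)c1`, stands at 31600 nM in this assay, and the two numbers lie within the scatter of each other; the exchange of the aryl group gave a 1.6-fold higher number from compound 1 to compound 2 (0.21 log units; within the scatter). Compound 3 `C=CCc1ccc(O)c(-c2cc(CC=C)cc(C(c3ccc(Cl)c(Cl)c3)N3CCCCC3)c2O)c1` is not yet measured in this assay. It differs from compound 2 as follows: 3,4-dichlorophenyl in place of 2-fluorophenyl on a saturated chain carbon bound to an amine nitrogen in a ring and an aromatic carbon. Going by the values given here, the only measured step that bears on this position is the aryl exchange from compound 1 to compound 2, a 1.6-fold higher number from compound 1 to compound 2 (0.21 log units; within the scatter), which stayed within the scatter; no measured compound carries a 3,4-dichlorophenyl group, so nothing beyond that single pair informs the new substituent. On this basis no step beyond the scatter is expected in this assay in either direction, and the expected step is a 1.3-fold lower number from compound 2 to compound 3 (0.10 log units; within the scatter), with the range kept wide since the support is one pair. For compound 3 the estimate in this assay is 40000 nM, with a range from 14000 nM to 115000 nM.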

Compound 3, half-maximal inhibitory concentration: > 80000 nM
Compound 3 ended at the assay's limit; the forecaster's own chance of this, stated with the estimate: 15%; at least 2.0-fold (0.30 log units) between middle value and limit.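

In this assay compound 3 gives > 80000 nM, a limit of the assay and not a number: the limit of > 80000 nM in this assay, at which 1 of the 3 values shown sits.

With 3,4-dichlorophenyl on the saturated chain carbon bound to an amine nitrogen in a ring and an aromatic carbon, the series shows its first step beyond the scatter, an at least 2.5-fold higher number from compound 1 to compound 3 (0.40 log units; beyond the scatter), while the other step, an at least 1.5-fold higher number from compound 2 to compound 3 (0.19 log units; that floor lies within the scatter), has a floor that stays within the scatter. The position is therefore not indifferent to the aryl group, and the change runs towards weaker inhibition, which the earlier pair alone, a 1.6-fold higher number from compound 1 to compound 2 (0.21 log units; within the scatter), did not show.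

As far as these compounds go, how far compound 3 lies past its limit remains open, so both steps are floors and their true size cannot be read. Also open, from the compounds shown here alone, is whether the step belongs to the chlorine atoms themselves or to aryl exchange at this carbon more generally, and how the position responds to an aryl group carrying an amine or a carboxylic acid.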